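The source may report more compounds than this note shows. Statements on the series, on what has been measured and on what is new or still open speak of the compounds shown alone.

In a functional assay on MCF-10A cells (Homo sapiens) for antiproliferative activity, with a stated time of 48 h (a higher number here means that more compound is needed for the effect, a lower number that less compound is needed), the measured values are:
- compound 1 (`COc1ccc2nc(C)cc(NCC3CCCN(C)C3)c2c1`) gives 5800 nM
- compound 2 (`COc1ccc2nc(C)cc(NCc3c(F)cccc3F)c2c1`) gives 13600 nM
- compound 3 (`COc1ccc2nc(C)cc(NCc3ccc(F)c(C(F)(F)F)c3)c2c1`) gives 14300 nM

Compound 3 stands within the usual scatter of compound 2, and its number lies beyond the scatter above that of compound 1. Compound 4 (`COc1ccc2nc(C)cc(NCc3ccc(F)c(OC)c3)c2c1`) has not yet been measured. It differs from compound 3 (methoxy in place of trifluoromethyl on an aromatic carbon) by having methoxy in place of trifluoromethyl on an aromatic carbon, ortho to a fluoro group and meta to a large group.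

For the measured compounds named here, no measured pair tests a single change of this kind. Compound 2 at 13600 nM and compound 3 at 14300 nM carry different groups on the aromatic ring yet stand within the scatter of each other, so no large shift is expected here. The estimated size of a 1.2-fold lower number from compound 3 to compound 4 (0.08 log units; within the scatter) is small, and this step is expected to stay within the scatter. In this assay compound 4 is estimated at 12000 nM (expected range 6000 nM to 24000 nM)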

Compound 4, half-maximal effective concentration: 12900 nM
Estimate against measurement, compound 4: 1.1-fold (0.03 log units) below, and the stated range covers the measured number.
By their numbers in this assay, from the lowest: compound 1; then compounds 4, 2 and 3 (each within the scatter of the next).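

In this assay, for the compounds shown here, the exchange of trifluoromethyl for methoxy on this aromatic carbon, ortho to a fluoro group and meta to a large group, gives a 1.1-fold lower number from compound 3 to compound 4 (0.04 log units; within the scatter), the first reading of a single change. At this place, then, a group of 4 heavy atoms with 0 hydrogen-bond acceptors and a group of 2 heavy atoms with 1 hydrogen-bond acceptor cannot be told apart in this assay. No measurement on hand accounts for this result.

Going by these compounds, whether an amine or a carboxylic acid on the same carbon would also stay within the scatter remains open. Also open, on these data alone, is whether the same exchange would read alike without the fluoro group on the ring.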